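Permeability Across Two Cores With One Shared Substituent Change

The compounds below may be only part of what the source reports. "The series", "measured", "known", "first", "only" and "open" are said of these compounds alone.

Of the compounds shown here, three have been measured in an ADME assay on Caco-2 cells (Homo sapiens) for permeability, read by LC-MS, in the apical to basolateral direction, with a stated time of 60 min, at pH 6.5; on this read-out higher numbers stand for higher permeability and lower numbers for lower permeability. Compound 2 `CC(C)(C)[C@@H](O)C(=O)N1N=CC[C@H]1C(=O)NCc1cc(Cl)ccc1-n1cnnn1` gives 15 10^-6 cm/s in this assay, and compound 1 `CC1(C[C@@H](O)C(=O)N2N=CC[C@H]2C(=O)NCc2cc(Cl)ccc2-n2cnnn2)CC1` gives 9.5 10^-6 cm/s. The change between them is (1-methylcyclopropyl)methyl in place of tert-butyl on a saturated chain carbon bound to a carbonyl carbon and an oxygen on a saturated carbon and it made a step of a 1.6-fold lower number from compound 2 to compound 1 (0.20 log units; within the scatter).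

Compound 3 `CC(C)(C)[C@@H](O)C(=O)N1C[C@H]2C[C@H]2[C@H]1C(=O)NCc1cc(Cl)ccc1-n1cnnn1` carries a different core; the difference between the two cores is not broken down here. In this assay compound 3 gives 3.8 10^-6 cm/s, which stands lowest of the three numbers, beyond the scatter from both compound 1 and compound 2.

Compound 4 `CC1(C[C@@H](O)C(=O)N2C[C@H]3C[C@H]3[C@H]2C(=O)NCc2cc(Cl)ccc2-n2cnnn2)CC1` has not yet been measured. It differs from compound 3 by (1-methylcyclopropyl)methyl in place of tert-butyl on a saturated chain carbon bound to a carbonyl carbon and an oxygen on a saturated carbon, the same change that was made from compound 2 to compound 1, at the same place. Since that earlier step of a 1.6-fold lower number from compound 2 to compound 1 (0.20 log units; within the scatter) stayed within the scatter, compound 4 is expected to sit close to compound 3, with a step of about a 1.3-fold lower number from compound 3 to compound 4 (0.10 log units; within the scatter). The estimate for compound 4 in this assay is 3 10^-6 cm/s, expected to fall between 1.5 10^-6 cm/s and 6 10^-6 cm/s.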

Compound 4, apparent permeability: 2.2 10^-6 cm/s
For compound 4 the middle estimate is 1.4-fold (0.13 log units) above the measured one; the measured number falls inside the stated range.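

In this assay, (1-methylcyclopropyl)methyl in place of tert-butyl gives a 1.7-fold lower number from compound 3 to compound 4 (0.24 log units; within the scatter), and set beside the earlier step, the change reads alike on the two cores: the same change on two cores in this assay, a 1.6-fold lower number (0.20 log units; within the scatter) from compound 2 to compound 1 and a 1.7-fold lower number (0.24 log units; within the scatter) from compound 3 to compound 4, 1.1-fold (0.04 log units) apart, within the scatter of two such steps. Each step lies within the scatter on its own, so the change carried from one core to the other without a shift that can be told apart from repeated measurement. This does not show that the change has a real effect on either core, and a single pair on each of two cores cannot show that it would read the same way on any further core.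

The compounds shown leave open how this place, on a saturated chain carbon bound to a carbonyl carbon and an oxygen on a saturated carbon, would read with an amine, a carboxylic acid or a longer chain instead of these two carbon-only groups. They also leave open which part of the core accounts for the gap between the numbers of compound 2 and compound 3.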